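Compound 1 to compound 4: a sulfonyl group on nitrogen

The source may report more compounds than this note shows. Statements on the series, on what has been measured and on what is new or still open speak of the compounds shown alone.

Measured in a functional assay on MV4-11 cells (Homo sapiens) for antiproliferative activity, read by resazurin assay, with a stated time of 72 h; a lower number here means a stronger inhibitor of growth, a higher number a weaker inhibitor of growth:
- compound 1 `CC(=O)N1CCN(c2ccc(Nc3nccc(-c4c[nH]c5ccccc45)n3)cc2)CC1`: 33 nM
- compound 2 `CC(=O)N1CCN(c2ccc(Nc3nccc(-c4nn(C)c5ccccc45)n3)cc2)CC1`: 181 nM
- compound 3 `CC(=O)N1CCN(c2ccc(Nc3nccc(-c4c[nH]c5ncccc45)n3)cc2)CC1`: < 1 nM (a limit of the assay, not a number)

Of the two true numbers, compound 1 holds the lower, and the gap to the other is a 5.5-fold higher number from compound 1 to compound 2 (0.74 log units; beyond the scatter).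

Compound 4 `CC(=O)N1CCN(c2ccc(Nc3nccc(-c4cn(S(=O)(=O)c5ccc(C)cc5)c5ccccc45)n3)cc2)CC1` differs from compound 1 in one place: (4-methylphenyl)sulfonyl in place of hydrogen on an aromatic nitrogen. In short, (4-methylphenyl)sulfonyl stands in place of hydrogen on an aromatic nitrogen.

Within the data shown here, two measured steps bear on this. The only one that loses that hydrogen is a 5.5-fold higher number from compound 1 to compound 2 (0.74 log units; beyond the scatter), although a ring atom changes there as well. The other, an at least 33-fold lower number from compound 1 to compound 3 (1.51 log units; beyond the scatter), keeps the hydrogen and is large, so the numbers in this series can move far on a small change to this group. Neither step brings in a group of the size entering here, so a rise beyond the modest one is expected, with wide uncertainty.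

The expected step is a 12-fold higher number from compound 1 to compound 4 (1.08 log units; beyond the scatter). For compound 4 the estimated value is 400 nM, with an expected range from 80 nM to 3000 nM.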

Compound 4, concentration for 50% growth inhibition: 1560 nM
Compound 4: the middle estimate sits 3.9-fold (0.59 log units) below what was measured, within the range that was stated.
By their numbers in this assay, from the lowest: compound 1; then compound 2; then compound 4. At a limit, below all of these: compound 3.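

In this assay, (4-methylphenyl)sulfonyl in place of hydrogen on the aromatic nitrogen gives a 47-fold higher number from compound 1 to compound 4 (1.67 log units; beyond the scatter). Among these compounds, this is the first step in which only this position changes, with no ring atom altered, so the loss of this hydrogen together with a large group can be read directly. The position still allows measurable growth inhibition with that group in place, as compound 4 gives 1560 nM.

Going by these compounds, whether the rise follows the loss of the hydrogen or the size of the entering group stays open, and an ethyl or a short chain ending in an amine on the same nitrogen of the core of compound 1 would separate the two. Whether the sulfonyl group costs as much on the core of compound 3, whose value is a limit and not a number, is also open: the limit of < 1 nM in this assay, at which 1 of the 4 values shown sits.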